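The compounds below may be only part of what the source reports. "The series", "measured", "known", "first", "only" and "open" are said of these compounds alone.

Of the compounds shown here, three sharing one core have been tested in a functional assay on HepG2 cells (Homo sapiens) for inhibition, read by MTT assay, with a stated time of 48 h; on this read-out lower numbers stand for stronger inhibition and higher numbers for weaker inhibition. Compound 1, `O=C(CSc1nnc(-c2ccncc2)n1-c1ccccc1)N/N=C/c1ccc(O)cc1`, gives only a limit of the assay, > 50000 nM. Compound 2, `O=C(CSc1nnc(-c2ccncc2)n1-c1ccccc1)N/N=C/c1ccccc1F`, gives 15200 nM in this assay. Compound 3, `O=C(CSc1nnc(-c2ccncc2)n1-c1ccccc1)N/N=C/c1cccc(F)c1`, gives 24400 nM in this assay, the higher of the two numbers recorded; its nearest neighbour is compound 2, and the step of a 1.6-fold higher number from compound 2 to compound 3 (0.21 log units; within the scatter) lies within the scatter, so no order between them can be claimed. The two measured steps from the limit of compound 1 are an at least 3.2-fold lower number from compound 1 to compound 2 (0.51 log units; beyond the scatter) and an at least 2.0-fold lower number from compound 1 to compound 3 (0.31 log units; beyond the scatter), and both point from a hydroxyphenyl to a fluorophenyl with a lower number.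

Compound 4, `O=C(CSc1nnc(-c2ccncc2)n1-c1ccccc1)N/N=C/c1ccc(O)c(O)c1`, has not yet been measured. It differs from compound 3 by 3,4-dihydroxyphenyl in place of 3-fluorophenyl on a carbon with a double bond to nitrogen. This change runs opposite to the step from compound 1 to compound 3, which replaced a hydroxyphenyl by a fluorophenyl and lowered the number. The reverse direction, returning hydroxyl groups to that ring, is therefore expected to raise the number in this assay, probably back toward the limit that compound 1 reached. For compound 4 the expected step is a 2.0-fold higher number from compound 3 to compound 4 (0.31 log units; beyond the scatter). Compound 4 is accordingly estimated at 50000 nM, within a range from 15000 nM to 150000 nM.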

Compound 4, half-maximal inhibitory concentration: 16900 nM
Beside the measured number, compound 4's estimate is 3.0-fold (0.47 log units) above it; measured number inside the range.
By their numbers in this assay, from the lowest: compounds 2, 4 and 3 (each within the scatter of the next). At a limit, above all of these: compound 1.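

In this assay, for the compounds shown here, the 3,4-dihydroxyphenyl group on the carbon with a double bond to nitrogen does not go with the weak end of the series, so the link between hydroxyphenyl and a higher number suggested by the earlier compounds does not hold for compound 4, which goes against it: hydroxy in place of hydrogen on an aromatic carbon gives an at least 2.9-fold lower number from compound 1 to compound 4 (0.47 log units; beyond the scatter). At this place, a ring with hydroxy groups cannot be told apart from either fluorophenyl ring, as a 1.4-fold lower number from compound 3 to compound 4 (0.16 log units; within the scatter) and a 1.1-fold higher number from compound 2 to compound 4 (0.05 log units; within the scatter) both stay within the scatter. On these data alone, compound 1 stands at a limit, so the true size of its step to compound 4 stays unknown: the limit of > 50000 nM in this assay, at which 1 of the 4 values shown sits.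

The compounds shown leave open whether any group at this place would move the number beyond the scatter of the fluorophenyl and 3,4-dihydroxyphenyl compounds, for instance an amine, a methoxy group or a carboxylic acid on the same aromatic ring. They also do not tell why the added hydroxy lowers the number relative to compound 1, or whether that step would hold on other rings.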